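Heteroaryl swap on the shared core: outlook for compound 4

The compounds below may be only part of what the source reports. "The series", "measured", "known", "first", "only" and "open" are said of these compounds alone.

In an in vitro assay on HEK385-7 cells for displacement of a labelled ligand from prostaglandin D2 receptor 2 (Homo sapiens) (on this read-out higher numbers stand for weaker inhibition and lower numbers for stronger inhibition), compound 1 `N#Cc1cc(-c2nc(C(c3ccc(F)cc3)c3ccc(F)cc3)sc2CC(=O)O)ccc1F` gives 57 nM, compound 2 `NS(=O)(=O)c1ccc(-c2nc(C(c3ccc(F)cc3)c3ccc(F)cc3)sc2CC(=O)O)cc1` gives 1500 nM and compound 3 `Nc1cc(-c2nc(C(c3ccc(F)cc3)c3ccc(F)cc3)sc2CC(=O)O)cc(F)n1` gives 220 nM. Compound 3 stands second highest of the three numbers; its nearest neighbour is compound 1, with a 3.9-fold higher number from compound 1 to compound 3 (0.59 log units; beyond the scatter), and its furthest is compound 2, with a 6.8-fold lower number from compound 2 to compound 3 (0.83 log units; beyond the scatter). The change from compound 3 to compound 4 `O=C(O)Cc1sc(C(c2ccc(F)cc2)c2ccc(F)cc2)nc1-c1ccnc(O)c1` is 2-hydroxypyridin-4-yl in place of 2-amino-6-fluoropyridin-4-yl on an aromatic carbon. Among the measured compounds shown here, no measured step exchanges one pyridin-4-yl for another, so the bearing of the known steps is indirect: a 26-fold higher number from compound 1 to compound 2 (1.42 log units; beyond the scatter) and a 3.9-fold higher number from compound 1 to compound 3 (0.59 log units; beyond the scatter) both show that replacing 3-cyano-4-fluorophenyl at this position gave higher numbers, the sulfamoylphenyl of compound 2 costing far more than the aminofluoropyridyl of compound 3. With the ring type retained, the expected step for compound 4 is small and leans toward a higher number, a 1.8-fold higher number from compound 3 to compound 4 (0.26 log units; within the scatter). In this assay compound 4 is estimated at 400 nM, with a range from 120 nM to 1300 nM.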

Compound 4, half-maximal inhibitory concentration: 68 nM
For compound 4 the middle estimate is 5.9-fold (0.77 log units) above the measured one; measured number outside the range, below it.
By their numbers in this assay, from the lowest: compounds 1 and 4 (each within the scatter of the next); then compound 3; then compound 2.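

In this assay, one pyridin-4-yl can be exchanged for another at this position with a step beyond the scatter (a 3.2-fold lower number from compound 3 to compound 4 (0.51 log units; beyond the scatter)), so the ring type alone does not set the number and the groups carried on the ring count. The 2-hydroxypyridin-4-yl group and the 3-cyano-4-fluorophenyl group lie within the scatter of each other (a 1.2-fold higher number from compound 1 to compound 4 (0.08 log units; within the scatter)), which shows that the nitrile-bearing benzene ring is not needed for a number at this level. The 4-sulfamoylphenyl group stays far apart from the 2-hydroxypyridin-4-yl group (a 22-fold lower number from compound 2 to compound 4 (1.34 log units; beyond the scatter)).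

Nothing measured beyond these numbers accounts for the step between the two pyridyl groups. As far as these compounds go, compound 3 and compound 4 differ at more than one ring atom, so it remains open whether the hydroxyl, the loss of the amine or the loss of the fluorine carries the step; a 2-aminopyridin-4-yl or 2-methoxypyridin-4-yl group at this position would separate these.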